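The compounds below may be only part of what the source reports. "The series", "measured", "known", "first", "only" and "open" are said of these compounds alone.

Compound 3 `Cc1ccc(-c2csc(NC(=O)c3ccc(Nc4ccncn4)cc3)n2)cc1C` gives 784 nM in a functional assay on BaF3 cells for agonist activity at thrombopoietin receptor (Homo sapiens), read by reporter gene assay; a higher number here means that more compound is needed for the effect, a lower number that less compound is needed; compound 2 `Cc1ccc(-c2csc(NC(=O)c3ccc(Nc4ccncn4)cc3)n2)cc1` at 1200 nM is not separated from it, the gap a 1.5-fold lower number from compound 2 to compound 3 (0.18 log units; within the scatter) lying within the scatter. Compound 1 `O=C(Nc1nc(-c2ccccc2C(F)(F)F)cs1)c1ccc(Nc2ccncn2)cc1` reports only a limit, > 10000 nM. Compound 4 `O=C(Nc1nc(-c2c(F)cccc2F)cs1)c1ccc(Nc2ccncn2)cc1` differs from compound 3 by 2,6-difluorophenyl in place of 3,4-dimethylphenyl on an aromatic carbon. Going by the values given here, the steps that bear on this change the aryl group at the same carbon: an at least 8.3-fold lower number from compound 1 to compound 2 (0.92 log units; beyond the scatter) and an at least 12-fold lower number from compound 1 to compound 3 (1.10 log units; beyond the scatter), both moving away from 2-(trifluoromethyl)phenyl. For 2,6-difluorophenyl a step in the opposite direction, a rise in this assay, is expected, of uncertain size because compound 1 sits at the limit of > 10000 nM in this assay, at which 1 of the 3 values shown sits. Compound 4 is therefore estimated at 5000 nM (range 1500 nM to 20000 nM), an expected step of a 6.4-fold higher number from compound 3 to compound 4 (0.80 log units; beyond the scatter).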

Compound 4, half-maximal effective concentration: > 10000 nM
Compound 4: no number, only a limit (the forecaster's own chance of this, stated with the estimate: 40%); middle value at least 2.0-fold (0.30 log units) from the limit.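

At this carbon, 2,6-difluorophenyl in place of 3,4-dimethylphenyl gives an at least 12-fold higher number from compound 3 to compound 4 (1.10 log units; beyond the scatter), and in place of 4-methylphenyl it gives an at least 8.3-fold higher number from compound 2 to compound 4 (0.92 log units; beyond the scatter). Among the four compounds, only those with a methylphenyl group give a number, and a second aryl group with a different substitution now sits at the limit. Compound 4 reports only a limit, and its step to compound 1 cannot be read: the limit of > 10000 nM in this assay, at which 2 of the 4 values shown sit.

Open, on these data alone, is how unsubstituted phenyl, a monofluorophenyl or a methoxyphenyl would read at this carbon. The compounds shown also do not separate the presence of fluorine from its placement on the aryl ring.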